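The source may hold more compounds than are shown below. What is called first, only, known or untested is meant among the compounds shown, and "the series" means these compounds.

Of the compounds shown here, three built on one shared core have been measured in a functional assay on PC-3 cells (Homo sapiens) for antiproliferative activity, read by MTT assay, with a stated time of 24 h; on this read-out lower numbers stand for stronger inhibition and higher numbers for weaker inhibition. Compound 1 `CCn1c(C(=O)NCCN)ccc1C(CC)(CC)c1ccc(OCS(=O)(=O)c2ccccc2)c(C)c1` carries a 2-aminoethyl group on its amide-type nitrogen, and in this assay compound 1 gives 6890 nM. Compound 2 `CCn1c(C(=O)NC(C)(C)CO)ccc1C(CC)(CC)c1ccc(OCS(=O)(=O)c2ccccc2)c(C)c1` carries 1-(hydroxymethyl)-1-methylethyl there, and compound 2 gives 9850 nM. Compound 3 `CCn1c(C(=O)N[C@H](CO)CCO)ccc1C(CC)(CC)c1ccc(OCS(=O)(=O)c2ccccc2)c(C)c1` carries 3-hydroxy-1-(hydroxymethyl)propyl, and compound 3 gives 12100 nM. Of these three numbers compound 2 holds the second highest, nearest to compound 3 and furthest from compound 1, yet all three sit within the scatter of one another.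

Compound 4 `CCn1c(C(=O)N[C@H](C(=O)O)C(C)C)ccc1C(CC)(CC)c1ccc(OCS(=O)(=O)c2ccccc2)c(C)c1` is not yet measured. It differs from compound 2 in one place: 1-carboxy-2-methylpropyl in place of 1-(hydroxymethyl)-1-methylethyl on an amide-type nitrogen. Within the data shown here, the steps that bear on this exchange all swap one substituent for another on the same amide-type nitrogen: a 1.4-fold higher number from compound 1 to compound 2 (0.16 log units; within the scatter), a 1.8-fold higher number from compound 1 to compound 3 (0.24 log units; within the scatter) and a 1.2-fold higher number from compound 2 to compound 3 (0.09 log units; within the scatter). None moved the number beyond the scatter, so no step beyond the scatter is expected here, in either direction. Compound 4 is estimated at 10000 nM, with a range from 4500 nM to 22000 nM. The step expected for compound 4 is a 1.0-fold higher number from compound 2 to compound 4 (0.01 log units; within the scatter), inside the scatter.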

Compound 4, half-maximal inhibitory concentration: 3650 nM
The estimate for compound 4 lay 2.7-fold (0.44 log units) above the measured number; measured number outside the range, below it.
By their numbers in this assay, from the lowest: compounds 4, 1, 2 and 3 (each within the scatter of the next, the first and the last beyond it).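

In this assay the amide-type nitrogen now shows steps beyond the scatter, which no exchange among the earlier three substituents did. Placing 1-carboxy-2-methylpropyl there gives a modest move from either hydroxyl-bearing substituent (a 2.7-fold lower number from compound 2 to compound 4 (0.43 log units; beyond the scatter); a 3.3-fold lower number from compound 3 to compound 4 (0.52 log units; beyond the scatter)), while the step from the 2-aminoethyl group stays within the scatter (a 1.9-fold lower number from compound 1 to compound 4 (0.28 log units; within the scatter)), so compound 4 and compound 1 cannot be told apart. No measurement available here accounts for these steps.

On these data alone, it remains open whether the steps belong to the carboxylic acid itself or to the rest of the 1-carboxy-2-methylpropyl chain, which a methyl ester or a primary amide on the same chain could separate. Also open, as far as these compounds go, are a carboxylic acid on a longer chain and the same group with its stereocentre inverted.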